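Lengthening the nitrogen-bound chain by one carbon

The source may hold more compounds than are shown below. What is called first, only, known or untested is meant among the compounds shown, and "the series" means these compounds.

Measured so far:
compound 1, `CC(C)CCn1ccc(N2CCC(c3ccccc3)CC2)c(C#N)c1=O`: 102 nM
compound 2, `N#Cc1c(N2CCC(c3ccccc3)CC2)ccn(CC2CC2)c1=O`: 151 nM

For the measured compounds named here, compound 2 gives the highest of the two numbers in a functional assay on CHO cells for positive allosteric modulation of metabotropic glutamate receptor 2 (Homo sapiens), with a stated time of 30 min (a higher number here means that more compound is needed for the effect, a lower number that less compound is needed), but its only neighbour, compound 1, sits within the scatter, so the two cannot be told apart. Going by the values given here, the one step so far, a 1.5-fold higher number from compound 1 to compound 2 (0.17 log units; within the scatter), swapped isobutyl for cyclopropyl on the saturated chain carbon bound to the aromatic nitrogen and changed little.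

Compound 3, `N#Cc1c(N2CCC(c3ccccc3)CC2)ccn(CCC2CC2)c1=O`, differs from compound 2 by cyclopropylmethyl in place of cyclopropyl on a saturated chain carbon bound to an aromatic nitrogen; seen one bond further out, the change reads cyclopropylmethyl to 2-cyclopropylethyl. Among the compounds with values here, the step from compound 1 to compound 2 is the only guide, and it bears on the same place; it suggests that this part of the molecule tolerates such variation. The expected step of a 1.3-fold higher number from compound 2 to compound 3 (0.10 log units; within the scatter) in this assay is therefore no larger than the scatter, direction uncertain. For compound 3 the estimate in this assay is 190 nM, with a range from 70 nM to 550 nM.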

Compound 3, half-maximal effective concentration: 178 nM
Compound 3: middle estimate off by 1.1-fold (0.03 log units), on the high side, within the range that was stated.
By their numbers in this assay, from the lowest: compounds 1, 2 and 3 (each within the scatter of the next).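

Lengthening the chain by one carbon, cyclopropylmethyl to 2-cyclopropylethyl, gives a 1.2-fold higher number from compound 2 to compound 3 (0.07 log units; within the scatter) in this assay, so this extra carbon has no effect that can be distinguished from the scatter. Cyclopropyl in place of isopropyl on a saturated chain carbon, two bonds along the chain from an aromatic nitrogen, gives a 1.7-fold higher number from compound 1 to compound 3 (0.24 log units; within the scatter) and likewise cannot be told apart, which means all three compounds now sit within the scatter of one another at this position. Nothing available explains this tolerance.

On these data alone, the groups compared here contain only carbon and hydrogen, so the effect of an amine or a carboxylic acid at this position remains open. As far as these compounds go, a much longer chain is also untested by these compounds, so how far this tolerance extends is unknown.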